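Chloro to bromo exchange in a cytotoxicity series

This account rests on a few compounds, and the source may have more. Where it says the series, first, only, none or still open, it means among the compounds named here.

Measured compounds in an ADME assay on 3T3-L1 cells (Mus musculus) for cytotoxicity, read by MTT assay, with a stated time of 48 h; a lower number here means a stronger inhibitor, a higher number a weaker inhibitor:
compound 1, `CC(=O)OC[C@H]1O[C@@H](SC(=S)C2=C(Nc3ccc(Cl)cc3Cl)CC(C)(C)CC2=O)[C@H](OC(C)=O)[C@@H](OC(C)=O)[C@@H]1OC(C)=O`: "not determined" (no result reported)
compound 2, `CC(=O)OC[C@H]1O[C@@H](SC(=S)C2=C(Nc3ccc(Cl)cc3)CC(C)(C)CC2=O)[C@H](OC(C)=O)[C@@H](OC(C)=O)[C@@H]1OC(C)=O`: > 20 ug/mL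
compound 3, `CC1(C)CC(=O)C=C(Nc2ccc(Br)cc2)C1`: "not determined" (no result reported)

Of the three compounds shown, only compound 2 carries an entry with a number attached, and that entry is a limit of the assay rather than a measured value. Within the data shown here, compound 1 and compound 3 have no result recorded, so no comparison between measured compounds can be drawn, and no step between them is known. The one thing that can be said is given by the limit of > 20 ug/mL in this assay, at which 1 of the 3 values shown sits; compound 2 sits at it, which places it among the weaker end of what this assay resolves.

Compound 4, `CC(=O)OC[C@H]1O[C@@H](SC(=S)C2=C(Nc3ccc(Br)cc3)CC(C)(C)CC2=O)[C@H](OC(C)=O)[C@@H](OC(C)=O)[C@@H]1OC(C)=O`, is the next entry to be tested. It differs from compound 2 by bromo in place of chloro on an aromatic carbon. The exchanged group keeps its position on the aromatic ring, and the remainder of the molecule is unchanged.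

Among the measured compounds shown here, with no measured step to lean on, the expectation for the step from compound 2 to compound 4 is a step that the limit leaves unreadable from compound 2 to compound 4, that is, nothing beyond the usual scatter of this assay is expected in either direction. Compound 4 is therefore expected to give 30 ug/mL, with a likely range from 14 ug/mL to 80 ug/mL, and a fair chance that this assay again returns only a limit for compound 4 rather than a number.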

Compound 4, half-maximal inhibitory concentration: > 20 ug/mL
Compound 4 gave a limit, no number; the forecaster's own chance of this, stated with the estimate: 70%; the middle value lies beyond the limit too.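

In this assay compound 4 gives > 20 ug/mL, which is a limit and not a number. Compound 2 also stands at a limit, > 20 ug/mL, so no step can be read between compound 2 and compound 4. The compounds shown leave open how the 4-chlorophenyl and 4-bromophenyl compounds compare, and at what concentration either reaches half-maximal inhibition.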